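This account rests on a few compounds, and the source may have more. Where it says the series, first, only, none or still open, it means among the compounds named here.

Measured so far:
Compound 1, `O=Cc1c(-c2ccccc2)nn(-c2ccccc2)c1/N=C/N1CCCC1`: in a functional assay on NPC-TW01 cells (Homo sapiens) for inhibition, read by MTT assay, with a stated time of 72 h (a higher number here means a weaker inhibitor of growth, a lower number a stronger inhibitor of growth), compound 1 gives > 50000 nM, which is a limit of the assay and not a number.
Compound 2, `CN/C=N/c1cc(-c2ccccc2)nn1-c1ccccc1`: in this assay compound 2 gives > 50000 nM, again a limit of the assay.

Compound 2 therefore stands at the limit of > 50000 nM in this assay, at which 2 of the 2 values shown sit. Among the compounds with values here, no numerical step between measured compounds is available; the two values show only that neither compound reached a measurable concentration for half-maximal growth inhibition.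

Compound 3, `CC/C(=N\c1cc(-c2ccccc2)nn1-c1ccccc1)NC`, is not yet measured. It differs from compound 2 by a group of 6 heavy atoms (4 carbon, 2 nitrogen; no ring) in place of a group of 4 heavy atoms (2 carbon, 2 nitrogen; no ring), on an aromatic carbon, in words: a group of 6 heavy atoms (4 carbon, 2 nitrogen; no ring) in place of a group of 4 heavy atoms (2 carbon, 2 nitrogen; no ring), on an aromatic carbon. With compound 2 already at the limit, no step beyond the scatter is expected in this assay, and compound 3 is expected most likely to return a limit as well. For compound 3 the estimate is 60000 nM, within 20000 nM to 200000 nM, which means an expected step that the limit leaves unreadable from compound 2 to compound 3.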

Compound 3, concentration for 50% growth inhibition: > 50000 nM
Compound 3: only a limit was reported; the forecaster's own chance of this, stated with the estimate: 75%; the middle value is on the limit's open side.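

Within the data shown here, compound 3 returns only a limit in this assay, as compound 2 does, so no step between these two compounds can be read: the limit of > 50000 nM in this assay, at which 3 of the 3 values shown sit. The compounds shown leave open which change on the shared core, if any, would bring growth inhibition to a measurable concentration.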